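The compounds below may be only part of what the source reports. "The series", "measured", "known", "first", "only" and "open" are said of these compounds alone.

The series shares one core and varies only in the group on an oxygen on an aromatic ring. Going by the values given here, compound 1 `CC(C)(O)CN1CCC(Oc2ccc([C@H]3CC[C@]4(CC3)OOC3(O4)C4CC5CC(C4)CC3C5)cc2)CC1` carries the 1-(2-hydroxy-2-methylpropyl)piperidin-4-yl group there; in an ADME assay on the whole organism (strain FVB) for pharmacokinetics, with Mus musculus as the target, read by LC-MS, at a dose of 30 mg/kg by the oral route (a higher number here means more compound in the circulation at the dose given, a lower number less compound in the circulation), compound 1 gives 1810 nM, the highest of the three numbers measured so far. Compound 2 `O[C@H]1CC[C@H](NCCCOc2ccc([C@H]3CC[C@]4(CC3)OOC3(O4)C4CC5CC(C4)CC3C5)cc2)CC1` gives 721 nM and compound 3 `CC(C)(N)CCOc1ccc([C@H]2CC[C@]3(CC2)OOC2(O3)C3CC4CC(C3)CC2C4)cc1` gives 1050 nM. Among the compounds with values here, the step of a 2.5-fold lower number from compound 1 to compound 2 (0.40 log units; beyond the scatter) is the only change beyond the scatter; the step of a 1.7-fold lower number from compound 1 to compound 3 (0.24 log units; within the scatter) and the step of a 1.5-fold higher number from compound 2 to compound 3 (0.16 log units; within the scatter) both lie within it.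

Compound 4 `CC(C)(O)CNCCCOc1ccc([C@H]2CC[C@]3(CC2)OOC2(O3)C3CC4CC(C3)CC2C4)cc1` is not yet measured. Relative to compound 1 the change is 3-((2-hydroxy-2-methylpropyl)amino)propyl in place of 1-(2-hydroxy-2-methylpropyl)piperidin-4-yl on an oxygen on an aromatic ring. Within the data shown here, two measured steps bear on this: opening the same ring to the 3-((4-hydroxycyclohexyl)amino)propyl chain in a 2.5-fold lower number from compound 1 to compound 2 (0.40 log units; beyond the scatter), and moving to the open 3-amino-3-methylbutyl chain in a 1.7-fold lower number from compound 1 to compound 3 (0.24 log units; within the scatter). Compound 4 keeps the 2-hydroxy-2-methylpropyl group of compound 1 but takes the propyl chain with an amine in it, as in compound 2. For compound 4 a small loss is therefore expected, lying between the two steps seen, roughly a 1.8-fold lower number from compound 1 to compound 4 (0.26 log units; within the scatter). For compound 4 the expected value is 1000 nM, with a range from 450 nM to 2200 nM.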

Compound 4, maximal plasma concentration: 1210 nM
The estimate for compound 4 lay 1.2-fold (0.08 log units) below the measured number; low and high end bracket the measured number.
By their numbers in this assay, from the lowest: compounds 2, 3, 4 and 1 (each within the scatter of the next, the first and the last beyond it).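

Holding the 2-hydroxy-2-methylpropyl group constant, replacing the 1-(2-hydroxy-2-methylpropyl)piperidin-4-yl group with the open 3-((2-hydroxy-2-methylpropyl)amino)propyl chain gives a 1.5-fold lower number from compound 1 to compound 4 (0.17 log units; within the scatter) in this assay, so at this position on an oxygen on an aromatic ring, the six-membered non-aromatic ring can be given up without a step beyond the scatter. On the amine nitrogen, 2-hydroxy-2-methylpropyl in place of 4-hydroxycyclohexyl gives a 1.7-fold higher number from compound 2 to compound 4 (0.22 log units; within the scatter), and the comparison with the 3-amino-3-methylbutyl chain gives a 1.2-fold higher number from compound 3 to compound 4 (0.06 log units; within the scatter); with both steps within the scatter, the single step beyond it among these compounds, a 2.5-fold lower number from compound 1 to compound 2 (0.40 log units; beyond the scatter), cannot be assigned to the loss of the ring or to the group on the nitrogen alone. Nothing available accounts for these numbers.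

Still open, from the compounds shown here alone, is whether the hydroxyl of the 2-hydroxy-2-methylpropyl group matters for this read-out, which a plain 2-methylpropyl group on the same amine nitrogen would address. Also open, going by these compounds, is how a butyl chain in place of the propyl chain on the oxygen would read in this assay.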